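Swapping one side group on a shared core

The source may report more compounds than this note shows. Statements on the series, on what has been measured and on what is new or still open speak of the compounds shown alone.

In a functional assay on HeLa cells (Homo sapiens) for cytotoxicity, read by MTT assay (a higher number here means a weaker inhibitor, a lower number a stronger inhibitor), compound 2 `CC(C)=CC[C@@H](OC(=O)CC(C)(O)C(C)C)C1=CC(=O)c2c(O)ccc(O)c2C1=O` gives 27700 nM and compound 1 `CCC(O)CO[C@H](CC=C(C)C)C1=CC(=O)c2c(O)ccc(O)c2C1=O` gives 28700 nM, so the two stand level. Compound 3 `CC[C@@](C)(O)CC(=O)O[C@H](CC=C(C)C)C1=CC(=O)c2c(O)ccc(O)c2C1=O` carries 1-hydroxy-1-methylpropyl in place of 1-hydroxy-1,2-dimethylpropyl on a saturated chain carbon bound to a carbonyl carbon. Going by the values given here, the only measured step, a 1.0-fold lower number from compound 1 to compound 2 (0.02 log units; within the scatter), exchanged a whole side group and stayed within the scatter, so no change beyond the scatter is expected in this assay here. The expected step is a 1.1-fold lower number from compound 2 to compound 3 (0.03 log units; within the scatter). For compound 3 the estimated value is 26000 nM, with an expected range of 12000 nM to 55000 nM.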

Compound 3, half-maximal inhibitory concentration: 17900 nM
Compound 3: the middle estimate sits 1.5-fold (0.16 log units) above what was measured; low and high end bracket the measured number.
By their numbers in this assay, from the lowest: compounds 3, 2 and 1 (each within the scatter of the next).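

Removing one methyl branch, with 1-hydroxy-1-methylpropyl in place of 1-hydroxy-1,2-dimethylpropyl, gives a small step in this assay (a 1.5-fold lower number from compound 2 to compound 3 (0.19 log units; within the scatter)). The wider exchange on the oxygen, (2-hydroxy-2-methylbutyl)carbonyl in place of 2-hydroxybutyl, also stays small (a 1.6-fold lower number from compound 1 to compound 3 (0.21 log units; within the scatter)). So neither a change inside the side group nor a swap of the whole group moves the number beyond the scatter among these three compounds, and no supporting measurement explains this. From the compounds shown here alone, whether an amine, a carboxylic acid or a longer chain here would shift the number remains open.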